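A few compounds are considered here, and "the series" means these few. Any claim that something is new, unique, unknown or untested is made for them only; others in the source may bear on it.

Measured compounds:
compound 1 `COc1cc(-c2cc(C(=O)/C=C/c3ccc(Cl)cc3)nc3cc(-c4ccccc4)nn23)cc(OC)c1OC`, 21600 nM
compound 2 `COc1ccc(-c2cc(C(=O)/C=C/c3ccc(Cl)cc3)nc3cc(-c4ccccc4)nn23)cc1OC`, 23700 nM
compound 3 `COc1ccc(-c2cc(/C=C/C(=O)c3ccccc3)nc3cc(-c4ccccc4)nn23)cc1`, 9900 nM

In a functional assay on MDA-MB-231 cells (Homo sapiens) for antiproliferative activity, read by MTT assay, with a stated time of 24 h (a higher number here means a weaker inhibitor, a lower number a stronger inhibitor), compound 1 gives 21600 nM, which stands second highest among the three numbers shown. Its nearest neighbour is compound 2, reached by a 1.1-fold higher number from compound 1 to compound 2 (0.04 log units; within the scatter), a change that is within the scatter. Within the data shown here, the furthest is compound 3, whose 9900 nM is a lower number than that of compound 1, beyond the scatter; no single-place step links these two.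

Compound 4 `COc1ccc(/C=C/C(=O)c2cc(-c3cc(OC)c(OC)c(OC)c3)n3nc(-c4ccccc4)cc3n2)cc1` differs from compound 1 by methoxy in place of chloro on an aromatic carbon. Among the measured compounds shown here, no measured step exchanges chloro for methoxy at that place. For the measured compounds named here, the only measured step, from compound 1 to compound 2, alters a methoxy elsewhere and stays within the scatter, so it gives no indication that a single substituent change on the shared core moves this assay much. Compound 3, which carries a methoxyphenyl, has a lower number, but its enone also runs the other way, so it bears only loosely.

Compound 4 is therefore expected to sit close to compound 1, with a 1.2-fold lower number from compound 1 to compound 4 (0.08 log units; within the scatter) not beyond the scatter, at an estimated 18000 nM within a range of 7000 nM to 45000 nM.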

Compound 4, half-maximal inhibitory concentration: 16500 nM
Compound 4: middle estimate off by 1.1-fold (0.04 log units), on the high side, within the range that was stated.
By their numbers in this assay, from the lowest: compounds 3, 4, 1 and 2 (each within the scatter of the next, the first and the last beyond it).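

Exchanging chloro for methoxy on the six-membered aromatic ring of carbon only, para to a large group, is the only step shown at this position, and in this assay it gives a 1.3-fold lower number from compound 1 to compound 4 (0.12 log units; within the scatter), so the 4-chlorophenyl and 4-methoxyphenyl forms cannot be told apart here. Alongside a 1.1-fold higher number from compound 1 to compound 2 (0.04 log units; within the scatter), which lies at a different place, this means neither single-place step shown moves the number beyond the scatter. Nothing at hand gives a reason for this result.

The compounds shown leave open whether an amine, a carboxylic acid or a longer alkoxy chain at this place would move the number beyond the scatter. They also leave open whether the exchange would read the same with the enone reversed, as in compound 3 (9900 nM), which differs from compound 1 in more than one place.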